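The compounds below may be only part of what the source reports. "The series", "measured", "known", "first", "only" and "open" are said of these compounds alone.

Working notes on the series, read in a functional assay (strain AB) with Danio rerio as the target, read by microscopy, with a stated time of 1 h; on this read-out higher numbers stand for an effect only at larger amounts of compound and lower numbers for an effect already at smaller amounts.

Compound 1 `CCN1CCc2c(sc(NC(=O)Nc3cccc(Cl)c3Cl)c2C(N)=O)C1` gives 17400 nM in this assay. Among the two numbers recorded, compound 1 stands highest; its nearest neighbour is compound 2 `CCN1CCc2c(sc(NC(=O)Nc3ccc4ccccc4c3)c2C(N)=O)C1`, which gives 1780 nM in this assay, a gap beyond the usual scatter. Compound 3 `CCN1CCc2c(sc(NC(=O)Nc3ccc(Cl)cc3)c2C(=O)O)C1` gives only a limit of the assay, > 25000 nM in this assay, and no number. That limit is noted as the limit of > 25000 nM in this assay, at which 1 of the 3 values shown sits, and is a boundary of the assay, not a measured value.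

The next compound, compound 4 `CCN1CCc2c(sc(NC(=O)Nc3ccc(Br)cc3)c2C(N)=O)C1`, has not yet been measured in this assay. It differs from compound 1 by 4-bromophenyl in place of 2,3-dichlorophenyl on an amide-type nitrogen. For the measured compounds named here, no measured pair in this set differs in one place, so no step of comparable kind is available to anchor the size of the change. Going by the values given here, the expectation is therefore a modest step in this assay, with a direction not settled by the compounds measured so far, and a real chance that only a limit is returned.

For compound 4 the step from compound 1 is expected to be a 1.5-fold lower number from compound 1 to compound 4 (0.16 log units; within the scatter). Compound 4 is expected to give about 12000 nM in this assay, within a range from 3000 nM to 40000 nM.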

Compound 4, half-maximal effective concentration: 3130 nM
The estimate for compound 4 lay 3.8-fold (0.58 log units) above the measured number; low and high end bracket the measured number.
By their numbers in this assay, from the lowest: compounds 2 and 4 (each within the scatter of the next); then compound 1. At a limit, above all of these: compound 3.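

The group on the amide-type nitrogen is now shown to matter in this assay: 4-bromophenyl in place of 2,3-dichlorophenyl gives a 5.6-fold lower number from compound 1 to compound 4 (0.75 log units; beyond the scatter). For the compounds shown here, this is the first step that can be read at a single place, and it shows that this position responds to an exchange of one aromatic group for another. No measurement shown bears on the reason for this step.

The exchange alters both the halogen and its placing on the ring, so the data do not separate these two changes. As far as these compounds go, it also remains open whether an unsubstituted phenyl or a 4-methoxyphenyl group on the same nitrogen of the core of compound 1 would give a number in line with compound 4.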